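Shortening the phenoxyalkyl chain: notes on four analogues

A few compounds are considered here, and "the series" means these few. Any claim that something is new, unique, unknown or untested is made for them only; others in the source may bear on it.

Measured so far in a functional assay on CHO cells for agonist activity at prostaglandin E2 receptor EP4 subtype (Homo sapiens), read by HTRF and cAMP accumulation, with a stated time of 30 min; a higher number here means that more compound is needed for the effect, a lower number that less compound is needed:
compound 1 `O=C(O)c1csc([C@H]2CC[C@@H]3[C@@H](/C=C/COc4ccccc4)[C@H](O)C[C@@H]3O2)n1` gives > 10000 nM, a limit of the assay and not a number.
compound 2 `O=C(O)c1csc([C@H]2CC[C@@H]3[C@@H](/C=C/CCCOc4ccccc4)[C@H](O)C[C@@H]3O2)n1` gives > 10000 nM, again a limit of the assay rather than a number.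
compound 3 `O=C(O)c1csc([C@H]2CC[C@@H]3[C@@H](CCCCCOc4ccccc4)[C@H](O)C[C@@H]3O2)n1` gives "not determined" (no result reported), that is, no result is reported for it in this assay.

Compounds 1 and 2 share the unsaturated chain and differ by phenoxy in place of 2-phenoxyethyl on a saturated chain carbon bound to a double-bonded chain carbon. The step that the two limits leave unreadable from compound 2 to compound 1 cannot be read, since both values sit at the limit of > 10000 nM in this assay, at which 2 of the 3 values shown sit. Nothing about the size of this change is therefore known from the measured pair.

Compound 3 carries the saturated chain instead; the difference between the cores of compound 2 and compound 3 is not broken down here. Compound 4 `O=C(O)c1csc([C@H]2CC[C@@H]3[C@@H](CCCOc4ccccc4)[C@H](O)C[C@@H]3O2)n1` is still to be measured in this assay and differs from compound 3 by phenoxy in place of 2-phenoxyethyl on a saturated chain carbon, three bonds along the chain from a saturated ring carbon. This is the same kind of change as that from compound 2 to compound 1, but not the same: in compound 1 the change sits on a saturated chain carbon bound to a double-bonded chain carbon, whereas in compound 4 it sits on a saturated chain carbon three bonds along the chain from a saturated ring carbon.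

Going by the values given here, for compound 4 no measured step gives a size to work from, and compound 3 offers no anchor. The expectation rests only on the two limits at the limit of > 10000 nM in this assay, at which 2 of the 3 values shown sit, in the unsaturated pair. Compound 4 is expected to fall around 10000 nM, estimated between 1000 nM and 50000 nM, with a real chance that only a limit is reported again.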

Compound 4, half-maximal effective concentration: > 10000 nM
Compound 4 ended at the assay's limit; the forecaster's own chance of this, stated with the estimate: 70%; the middle value lies on the limit itself.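

In this assay compound 4 gives > 10000 nM, a limit of the assay and not a number. Going by these compounds alone, with no result reported for compound 3, no step from compound 3 to compound 4 can be read. The compounds shown leave open whether phenoxy in place of 2-phenoxyethyl changes the half-maximal effective concentration at all, on either chain, and how far compounds 1, 2 and 4 lie from a measurable response.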